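A few compounds are considered here, and "the series" means these few. Any claim that something is new, unique, unknown or untested is made for them only; others in the source may bear on it.

Compound 1, `COc1cc2c(cc1OC)C(CC(=O)Nc1ccc(Cl)cc1)CC2`: 60.9%
Compound 2, `COc1cc2c(cc1OC)C(CC(=O)Nc1ccc(C)cc1)CC2`: 32.8%

Both compounds were tested in a functional assay on the whole organism (strain Wistar) for inhibition, with Rattus norvegicus as the target, read by paw edema, with a stated time of 4 h, at a dose of 100 mg/kg; on this read-out higher numbers stand for more inhibition at the one dose given (going by the name of the read-out) and lower numbers for less inhibition. Within the data shown here, compound 1 gives 60.9%, and compound 2 gives 32.8%, the lower of the two numbers; the only measured step, a number 28.1 percentage points lower from compound 1 to compound 2 (beyond the scatter), lies beyond the scatter. Compound 3, `COc1cc2c(cc1OC)C(CC(=O)Nc1ccc([N+](=O)[O-])cc1)CC2`, has not yet been measured. It differs from compound 2 in one place: nitro in place of methyl on an aromatic carbon. Among the measured compounds shown here, the one measured step bears on this only loosely: it shows that exchanging the group on the same aromatic carbon can shift the number by a modest amount, but nitro has not been tested here, so the direction of its effect is not known from these data. The expectation is therefore placed between the two measured numbers with a wide range, because the step of a number 28.1 percentage points lower from compound 1 to compound 2 (beyond the scatter) shows how far one change at that aromatic carbon can move the result. Compound 3 is expected to give 50%, between 28% and 70%, which means an expected step of a number 17.2 percentage points higher from compound 2 to compound 3 (beyond the scatter).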

Compound 3, a percentage reported as inhibition, in the whole organism at one dose (the size of the read-out at that dose, not a potency): 37.5%
Estimate against measurement, compound 3: 12.5 percentage points above, and the stated range covers the measured number.
By their numbers in this assay, from the lowest: compounds 2 and 3 (each within the scatter of the next); then compound 1.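

In this assay, nitro in place of methyl gives a number 4.7 percentage points higher from compound 2 to compound 3 (within the scatter), so at this aromatic carbon, two groups that differ in size and in hydrogen-bond acceptors are not told apart by this read-out. Compound 1 now stands apart from both other compounds: nitro in place of chloro gives a number 23.4 percentage points lower from compound 1 to compound 3 (beyond the scatter), which puts chloro alone with the higher number among these three groups. Nothing available here explains why chloro differs from methyl and nitro.

The compounds shown leave open whether the higher number of compound 1 belongs to chloro alone or would also appear with another halogen, such as fluoro or bromo. They also leave open how an amine or a methoxy group on the same carbon would compare.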